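A few compounds are considered here, and "the series" means these few. Any claim that something is new, unique, unknown or untested is made for them only; others in the source may bear on it.

Compound 1 `COc1cccc(-c2nc(SC)nc3sc(C(=O)N(C)C(C)(C)C)c(N)c23)c1` gives 47.8% in a functional assay on HEK293 cells for agonist activity at lutropin-choriogonadotropic hormone receptor (Homo sapiens), read by cAMP accumulation; on this read-out higher numbers stand for larger maximal responses and lower numbers for smaller maximal responses.
Compound 2 `COc1cccc(-c2nc(SC)nc3sc(C(=O)NCCO)c(N)c23)c1` gives 20.5% in this assay.

Of the two measured compounds, compound 2 stands lowest in this assay, and its nearest neighbour, compound 1, lies beyond the scatter above it, as the step of a number 27.3 percentage points lower from compound 1 to compound 2 (beyond the scatter) shows. Compound 3 `COc1cccc(-c2nc(SC)nc3sc(C(=O)OC(C)(C)C)c(N)c23)c1` is the unmeasured compound and differs from compound 2 in one place: tert-butoxy in place of (2-hydroxyethyl)amino on a carbonyl carbon. Within the data shown here, the only measured step that bears on this change is a number 27.3 percentage points lower from compound 1 to compound 2 (beyond the scatter), in which the group bearing a tert-butyl was exchanged for the (2-hydroxyethyl)amino group and the maximal response fell by a modest amount beyond the scatter. Compound 3 moves the other way, restoring a tert-butyl-bearing group on the carbonyl carbon, though as tert-butoxy rather than methyl(tert-butyl)amino. An increase in this assay is therefore expected for compound 3, of a size similar to but less certain than the earlier step, so that compound 3 is estimated at 40%, within 20% to 60%. This estimate means an expected step of a number 19.5 percentage points higher from compound 2 to compound 3 (beyond the scatter).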

Compound 3, largest response reached (reported as efficacy), in percent of the reference or control that the assay uses: 23.8%
The estimate for compound 3 lay 16.2 percentage points above the measured number; measured number inside the range.
By their numbers in this assay, from the lowest: compounds 2 and 3 (each within the scatter of the next); then compound 1.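

In this assay, the tert-butyl group alone does not restore the response on this carbonyl carbon: with tert-butoxy in place of methyl(tert-butyl)amino, the result is (a number 24 percentage points lower from compound 1 to compound 3 (beyond the scatter)). The exchange of (2-hydroxyethyl)amino for tert-butoxy gives (a number 3.3 percentage points higher from compound 2 to compound 3 (within the scatter)), so these two quite different groups, one with hydrogen-bond donors and one with none, leave compounds 2 and 3 level, and among these three compounds only the methyl(tert-butyl)amino group of compound 1 stands apart. No measurement at hand accounts for the gap between the amide of compound 1 and the ester of compound 3.

As far as these compounds go, what remains open is which part of the methyl(tert-butyl)amino group goes with the larger response of compound 1, a question that tert-butylamino, dimethylamino or piperidine-1-yl on the same carbonyl carbon would begin to separate. Also open, from the compounds shown here alone, is how a free carboxylic acid or a simple methoxy group at this place would compare with tert-butoxy, and whether other amines bearing a longer chain than (2-hydroxyethyl)amino would stay level with compound 2.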